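A few compounds are considered here, and "the series" means these few. Any claim that something is new, unique, unknown or untested is made for them only; others in the source may bear on it.

Working notes on the dichloroacetamide series. In a functional assay on A549 cells (Homo sapiens) for cytotoxicity, read by MTT assay, with a stated time of 68 h (on this read-out higher numbers stand for weaker inhibition and lower numbers for stronger inhibition), compound 1 `O=C(Nc1cccc(-c2ccc(F)cc2)c1)C(Cl)Cl` gives 7840 nM, and compound 3 `CSc1cccc(-c2cc(NC(=O)C(Cl)Cl)cc(-c3cccc(SC)c3)c2)c1` gives 15900 nM. Compound 2 `O=C(Nc1cccc(-c2ccsc2)c1)C(Cl)Cl` returns no number in this assay but only the limit of the assay, > 50000 nM. Compound 2 thus sits at the limit of > 50000 nM in this assay, at which 1 of the 3 values shown sits, which is the weakest end of the three values shown, while compound 1 and compound 3 each return a measured value.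

Compound 4 `O=C(Nc1cccc(-c2ccoc2)c1)C(Cl)Cl` is not yet measured. It differs from compound 2 in a single place: furan-3-yl in place of thiophen-3-yl on an aromatic carbon. Both groups that leave and enter carry the same count of heavy atoms, donors and acceptors, so no reason appears in the measured compounds for a move away from the limit, and none beyond the usual scatter is expected in this assay.

For compound 4 the expectation is that this assay again reports the limit or a value close to it, because compound 2 gives > 50000 nM. The step from compound 2 to compound 4 is estimated as a number no higher from compound 2 to compound 4 (the limit leaves the size open). Compound 4 is estimated at 50000 nM, within a range from 20000 nM to 100000 nM.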

Compound 4, half-maximal inhibitory concentration: 8480 nM
The estimate for compound 4 lay 5.9-fold (0.77 log units) above the measured number, outside the stated range (below it).
By their numbers in this assay, from the lowest: compounds 1, 4 and 3 (each within the scatter of the next, the first and the last beyond it). At a limit, above all of these: compound 2.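

Furan-3-yl in place of thiophen-3-yl gives an at least 5.8-fold lower number from compound 2 to compound 4 (0.77 log units; beyond the scatter) in this assay, the first step in the series that can be read at this position. The position on the aromatic carbon therefore responds to an exchange of sulfur for oxygen in the five-membered ring, even though the heavy-atom, donor and acceptor counts stay the same. Compound 2 stands at a limit of the assay and not at a number, so the full size of the step remains unread: the limit of > 50000 nM in this assay, at which 1 of the 4 values shown sits.

The compounds shown do not tell why this exchange separates the two compounds, nor whether it would carry over to the core of compound 3. They also leave open how an amine or a carboxylic acid on the furan-3-yl ring would read in this assay.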